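The compounds below may be only part of what the source reports. "The series", "measured", "known", "first", "only" and "open" are said of these compounds alone.

Compound 1 `COc1ccc(/C=C2/C(=O)N(c3ccc(Cl)cc3)N=C2C)c(OC)c1`: in an assay for inhibition of Alpha amylase (Homo sapiens), with a stated time of 10 min (on this read-out higher numbers stand for weaker inhibition and lower numbers for stronger inhibition), compound 1 gives 2010 nM.
Compound 2 `COc1cc(/C=C2/C(=O)N(c3ccc(Cl)cc3)N=C2C)cc(OC)c1`: in this assay compound 2 gives 2210 nM.

Among the compounds with values here, of these two numbers compound 2 holds the higher one, yet its only neighbour, compound 1, sits within the scatter of it, so the two values show nothing that separates them. Compound 3 `COc1cc(/C=C2/C(=O)N(c3ccc(Cl)cc3)N=C2C)cc(OC)c1Br` differs from compound 2 by bromo in place of hydrogen on an aromatic carbon. Within the data shown here, no measured pair in this set carries that same change, so there is no step to lean on. On that thin footing the step from compound 2 to compound 3 in this assay is expected to be small, in either direction, and most likely not beyond the scatter, which is what a 1.2-fold lower number from compound 2 to compound 3 (0.07 log units; within the scatter) amounts to. Compound 3 is therefore estimated at 1900 nM, with a range from 700 nM to 5000 nM.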

Compound 3, half-maximal inhibitory concentration: 1680 nM
Compound 3: the middle estimate sits 1.1-fold (0.05 log units) above what was measured; measured number inside the range.
By their numbers in this assay, from the lowest: compounds 3, 1 and 2 (each within the scatter of the next).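

The earlier compounds shown here carried only hydrogen on this aromatic carbon, ortho to two methoxy groups and para to a large group. Within the data shown here, compound 3 is the first to place a heavy atom there: in this assay, bromo in place of hydrogen gives a 1.3-fold lower number from compound 2 to compound 3 (0.12 log units; within the scatter) and so leaves the number indistinguishable from that of compound 2. Among these compounds, a single bromine atom at this position is therefore accommodated with no step that can be told from the scatter, though this rests on one pair alone. Nothing available here bears on why the step is this small. Still open, from the compounds shown here alone, is whether an amine, a carboxylic acid or a longer chain on this same carbon would move the number beyond the scatter. Also open, going by these compounds, is whether bromo would give a similar step on the methoxy pattern of compound 1.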